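Swapping Chloro for Methyl at a Cytotoxicity Limit

A few compounds are considered here, and "the series" means these few. Any claim that something is new, unique, unknown or untested is made for them only; others in the source may bear on it.

Compound 2 `Cc1nc(-c2cccnc2)sc1-c1nnc(-c2ccc(Cl)cc2)o1` has been tested in an ADME assay on THP-1 cells (Homo sapiens) for cytotoxicity, read by MTT assay; on this read-out higher numbers stand for lower toxicity in this test and lower numbers for higher toxicity in this test. In this assay compound 2 gives > 100 ug/mL, which is a limit of the assay and not a number. Among the compounds with values here, its one measured relative is compound 1 `Cc1nc(-c2cccnc2)sc1-c1nnc(Cc2ccccc2)o1`. In this assay compound 1 gives > 100 ug/mL, again a limit rather than a number. The step that the two limits leave unreadable from compound 1 to compound 2 therefore cannot be sized, because of the limit of > 100 ug/mL in this assay, at which 2 of the 2 values shown sit. Compound 3 `Cc1ccc(-c2nnc(-c3sc(-c4cccnc4)nc3C)o2)cc1` is the next compound, and it differs from compound 2 by methyl in place of chloro on an aromatic carbon. Within the data shown here, no measured step bears directly on this change, and the only step available is unreadable, so nothing suggests a move beyond the scatter in either direction. The step that the limit leaves unreadable from compound 2 to compound 3 is expected to be none beyond the scatter. Compound 3 is estimated at 150 ug/mL, within 80 ug/mL to 300 ug/mL, most likely reported once more as a limit.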

Compound 3, half-maximal cytotoxic concentration: > 100 ug/mL
Compound 3 gave a limit, no number; the forecaster's own chance of this, stated with the estimate: 85%; the middle value is on the limit's open side.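

No new step can be read among compound 1, compound 2 and compound 3, because all three give a limit rather than a number in this assay: (the limit of > 100 ug/mL in this assay, at which 3 of the 3 values shown sit). From the compounds shown here alone, whether the benzyl, 4-chlorophenyl and 4-methylphenyl compounds differ at all in toxicity in this test stays open.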